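This account rests on a few compounds, and the source may have more. Where it says the series, first, only, none or still open, it means among the compounds named here.

Measured compounds in an ADME assay on HUVEC cells (Homo sapiens) for antiproliferative activity, read by MTT assay, with a stated time of 48 h; a higher number here means a weaker inhibitor, a lower number a stronger inhibitor:
- compound 1, `Cc1ccccc1-n1nncc1CN1C(=O)C2(C(C#N)=C(N)Oc3c2c2nc4ccccc4nc2c2ccccc32)c2ccccc21`; in this assay compound 1 gives > 50000 nM, which is a limit of the assay and not a number.
- compound 2, `Cc1cccc(-n2nncc2CN2C(=O)C3(C(C#N)=C(N)Oc4c3c3nc5ccccc5nc3c3ccccc43)c3ccccc32)c1`; in this assay compound 2 gives > 50000 nM, again a limit.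
- compound 3, `COc1ccc(-n2nncc2CN2C(=O)C3(C(C#N)=C(N)Oc4c3c3nc5ccccc5nc3c3ccccc43)c3ccccc32)cc1`; in this assay compound 3 gives > 50000 nM, again a limit.

Compound 3 thus stands at the same limit as the two others; all three values sit at the limit of > 50000 nM in this assay, at which 3 of the 3 values shown sit. The steps a step that the two limits leave unreadable from compound 1 to compound 2, a step that the two limits leave unreadable from compound 1 to compound 3 and a step that the two limits leave unreadable from compound 2 to compound 3 are therefore unreadable in size, and none of the three ring substituents on the aromatic nitrogen has moved a value into the measurable range.

Compound 4, `CCOc1ccccc1-n1nncc1CN1C(=O)C2(C(C#N)=C(N)Oc3c2c2nc4ccccc4nc2c2ccccc32)c2ccccc21`, is not yet measured. It differs from compound 3 by 2-ethoxyphenyl in place of 4-methoxyphenyl on an aromatic nitrogen. The three measured steps, all between limits, bear on this change only in that every variation of the substituent on the aromatic nitrogen has so far stayed at the limit. No readable step in this assay is expected from compound 3 to compound 4, with a step that the limit leaves unreadable from compound 3 to compound 4 as the nominal expectation. For compound 4 the estimate in this assay is 80000 nM, within 30000 nM to 250000 nM, most probably reported again as a limit.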

Compound 4, half-maximal inhibitory concentration: > 50000 nM
Compound 4: no number, only a limit (the forecaster's own chance of this, stated with the estimate: 85%); the middle value does not contradict the limit.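

In this assay compound 4 gives > 50000 nM, a limit and not a number. No step from compound 1, compound 2 or compound 3 to compound 4 can be read, as all four stand at one value: the limit of > 50000 nM in this assay, at which 4 of the 4 values shown sit.

The compounds shown leave open whether any substituent on the aromatic nitrogen brings this core into the measurable range.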